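The source may report more compounds than this note shows. Statements on the series, on what has been measured and on what is new or still open speak of the compounds shown alone.

Three closely related compounds have been measured in a functional assay on HT-29 cells (Homo sapiens) for cytotoxicity; a higher number here means that more compound is needed for the effect, a lower number that less compound is needed. Compound 1 `COc1cc(/C=C\c2ccc(C(C)C)cc2)cc(OC)c1OC` gives 2.4 uM, compound 3 `CCCOc1ccc(/C=C\c2cc(OC)c(OC)c(OC)c2)cc1` gives 2.8 uM, and compound 2 `COc1cc(/C=C/c2ccc(SC)cc2)cc(OC)c1OC` gives 8.3 uM. Compound 3 therefore sits level with compound 1, within the scatter, while the number of compound 2 is higher than that of compound 3 by more than the scatter.

The next compound, compound 4 `COc1cc(/C=C\c2ccc(SC)cc2)cc(OC)c1OC`, keeps the core of compound 3 but has methylsulfanyl in place of propoxy on an aromatic carbon. One measured step involves a similar exchange of a single group. The step of a 1.2-fold higher number from compound 1 to compound 3 (0.07 log units; within the scatter) puts propoxy in place of isopropyl on an aromatic carbon and stays within the scatter. Among the measured compounds shown here, this is only one step, so it is a thin guide.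

Compound 2 carries the same methylsulfanyl group, but its central double bond has the other geometry, so its 8.3 uM cannot be read as a direct preview. No change beyond the scatter is therefore expected in this assay, and the estimated change is a 1.4-fold lower number from compound 3 to compound 4 (0.15 log units; within the scatter). For compound 4 the expected value is 2 uM, with an estimated range from 0.5 uM to 6 uM.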

Compound 4, concentration for half-maximal effect: 1.8 uM
Beside the measured number, compound 4's estimate is 1.1-fold (0.05 log units) above it; low and high end bracket the measured number.
By their numbers in this assay, from the lowest: compounds 4, 1 and 3 (each within the scatter of the next); then compound 2.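

In this assay, the place on an aromatic carbon para to a large group accepts methylsulfanyl much as it accepts the two groups seen there earlier: a 1.6-fold lower number from compound 3 to compound 4 (0.19 log units; within the scatter), and a 1.3-fold lower number from compound 1 to compound 4 (0.12 log units; within the scatter). Both steps stay within the scatter, so propoxy, isopropyl and methylsulfanyl cannot be told apart here, even though the exchange for propoxy replaces a group of 4 heavy atoms with one of 2 heavy atoms. The geometry of the central double bond does show a difference beyond the scatter, a 4.6-fold lower number from compound 2 to compound 4 (0.66 log units; beyond the scatter), and this gap can be assigned to that double bond alone, on this ground: the fact that compounds 2 and 4 differ only in the configuration as drawn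

As far as these compounds go, this comparison of the two geometries rests on a single pair, so it remains open whether the E form would give a similar rise in the number with propoxy or isopropyl in place of methylsulfanyl. From the compounds shown here alone, it is also open whether an amine, a carboxylic acid or a longer chain at this same place would stay within the scatter of these three groups or move the number beyond it.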